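The source may hold more compounds than are shown below. What is called first, only, known or untested is meant among the compounds shown, and "the series" means these compounds.

Measured compounds:
compound 2 `COCCC(=O)N[C@@H]1CC[C@@H](Nc2ncc3c(Br)nn(-c4ccc5ncccc5c4)c3n2)C1` — 159 nM
compound 3 `CNS(=O)(=O)[C@@H]1CC[C@@H](Nc2ncc3c(Br)nn(-c4ccc5ncccc5c4)c3n2)C1` — 106 nM
compound 1 `COCCNC(=O)CCNc1ncc2c(Br)nn(-c3ccc4ncccc4c3)c2n1` — "nd" (no result reported)

Among the measured compounds shown here, all share one core; compound 1 is the only one whose five-membered ring is opened into a chain. In an assay on SK-OV-3 cells for inhibition of eIF-2-alpha kinase GCN2 (Homo sapiens) (on this read-out higher numbers stand for weaker inhibition and lower numbers for stronger inhibition), compound 3 gives the lowest of the two numbers, but a 1.5-fold lower number from compound 2 to compound 3 (0.18 log units; within the scatter) lies within the scatter, so compound 2 and compound 3 cannot be ranked. Compound 4 `CNC(=O)[C@@H]1CC[C@@H](Nc2ncc3c(Br)nn(-c4ccc5ncccc5c4)c3n2)C1` carries methylcarbamoyl in place of methylsulfamoyl on a saturated ring carbon. For the measured compounds named here, only the step from compound 2 to compound 3 bears on this, since it also swaps a carbonyl-bearing group for the methylsulfamoyl on the same ring carbon, and it stayed within the scatter. The expected step of a 1.4-fold higher number from compound 3 to compound 4 (0.15 log units; within the scatter) is therefore small. Compound 4 is estimated at 150 nM, between 60 nM and 400 nM.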

Compound 4, half-maximal inhibitory concentration: 25 nM
Compound 4: middle estimate off by 6.0-fold (0.78 log units), on the high side; the measured number lies below the stated range.
By their numbers in this assay, from the lowest: compound 4; then compounds 3 and 2 (each within the scatter of the next).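

In this assay the group on this saturated ring carbon turns out to matter: a 4.2-fold lower number from compound 3 to compound 4 (0.63 log units; beyond the scatter) comes with methylcarbamoyl replacing methylsulfamoyl, and a 6.4-fold lower number from compound 2 to compound 4 (0.80 log units; beyond the scatter) comes with it replacing ((2-methoxyethyl)carbonyl)amino. Compound 2 and compound 3 could not be ranked, so among these three only methylcarbamoyl stands apart, with the lowest number. Nothing measured here accounts for this difference. On these data alone, whether a carboxylic acid, an amine or a longer chain on this ring carbon would give a lower number or a higher one remains open.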